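The source may report more compounds than this note shows. Statements on the series, on what has been measured and on what is new or still open speak of the compounds shown alone.

In a toxicity assay on CCRF-CEM cells (Homo sapiens) for cytotoxicity (on this read-out higher numbers stand for lower toxicity in this test and lower numbers for higher toxicity in this test), three compounds with a shared core have been measured so far. Compound 1 `Cc1cccc2c1nc(-c1c(F)cccc1F)n2Cc1c(F)cccc1F`, which carries methyl on the aromatic carbon that varies, gives > 100 uM, a limit of the assay and not a number. Compound 2 `Oc1cccc2c1nc(-c1c(F)cccc1F)n2Cc1c(F)cccc1F`, which carries hydroxy there, gives > 100 uM, also a limit. Among the measured compounds shown here, compound 3 `Nc1cccc2c1nc(-c1c(F)cccc1F)n2Cc1c(F)cccc1F`, which carries amino, gives 26.3 uM, the only actual number of the three and the most toxic result in the set.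

Compound 4 `Fc1cccc(F)c1Cn1c(-c2c(F)cccc2F)nc2c(Cl)cccc21` has chloro in place of amino on an aromatic carbon. For the measured compounds named here, no chloro compound has yet been measured, so the guide is indirect. Hydroxy in place of methyl gave a step that the two limits leave unreadable from compound 1 to compound 2. Amino in place of methyl gave an at least 3.8-fold lower number from compound 1 to compound 3 (0.58 log units; beyond the scatter), and amino in place of hydroxy gave an at least 3.8-fold lower number from compound 2 to compound 3 (0.58 log units; beyond the scatter). Thus, of the three groups, only amino has brought a number below the limit, and compound 4 loses that group. A move back toward lower toxicity is therefore expected, though its size cannot be read from two limits. The expected change is a 3.0-fold higher number from compound 3 to compound 4 (0.48 log units; beyond the scatter). The assay may well report only a limit. For compound 4 the estimated value is 80 uM, with an expected range from 30 uM to 200 uM.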

Compound 4, half-maximal toxic concentration: 30.4 uM
Compound 4: middle estimate off by 2.6-fold (0.42 log units), on the high side, within the range that was stated.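

In this assay, chloro and amino on this aromatic carbon cannot be told apart, the change being a 1.2-fold higher number from compound 3 to compound 4 (0.06 log units; within the scatter). Amino is therefore no longer the only group at this position with a number under the limit, and the hydrogen-bond donor and acceptor counted on amino leave with it without a shift beyond the scatter. Against the other two groups, chloro gives an at least 3.2-fold lower number from compound 2 to compound 4 (0.51 log units; beyond the scatter) and an at least 3.2-fold lower number from compound 1 to compound 4 (0.51 log units; beyond the scatter), so the four compounds now fall into two sets, with amino and chloro on one side and methyl and hydroxy on the other.

On these data alone, how far methyl and hydroxy lie from each other, and how far either lies from amino and chloro beyond the smallest gap printed, cannot be read because both compounds sit at a limit and not at a number: the limit of > 100 uM in this assay, at which 2 of the 4 values shown sit. It also remains open whether a bromo, a methoxy or a nitrile on this aromatic carbon would join chloro and amino or methyl and hydroxy, and what separates the two sets cannot be told from these four compounds.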